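A few compounds are considered here, and "the series" means these few. Any claim that something is new, unique, unknown or untested is made for them only; others in the source may bear on it.

Working notes on the series. The shared core appears in compound 1 `COc1ccc(C(=O)CSc2nnc(-c3cc(OC)c(OC)c(OC)c3)n2-c2ccc(OC)cc2)cc1`, compound 2 `COc1ccc(-n2c(SCC(=O)c3ccc4ccccc4c3)nnc2-c2cc(OC)c(OC)c(OC)c2)cc1` and compound 3 `CCSc1nnc(-c2cc(OC)c(OC)c(OC)c2)n1-c1ccc(N(C)C)cc1`. In a functional assay on PC-3 cells (Homo sapiens) for inhibition, read by MTT assay, with a stated time of 48 h (on this read-out higher numbers stand for weaker inhibition and lower numbers for stronger inhibition), compound 1 gives > 60000 nM, which is a limit of the assay and not a number. In this assay compound 2 gives > 60000 nM, likewise a limit. The step that the two limits leave unreadable from compound 1 to compound 2 is therefore unreadable. In this assay, for the measured compounds named here, compound 3 gives 46200 nM, the only number among the three values. The other two values sit at the limit of > 60000 nM in this assay, at which 2 of the 3 values shown sit.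

Compound 4 `CCOC(=O)CSc1nnc(-c2cc(OC)c(OC)c(OC)c2)n1-c1ccc(N(C)C)cc1` has not been measured. It differs from compound 3 by ethoxycarbonyl in place of methyl on a saturated chain carbon bound to a sulfur. Going by the values given here, no measured step covers this change, and the one step that exists between two limits cannot be read. Compound 4 is expected to show either no step beyond the scatter or a move toward weaker inhibition, with a 1.2-fold higher number from compound 3 to compound 4 (0.08 log units; within the scatter). Compound 4 is estimated at 55000 nM, between 20000 nM and 100000 nM, with a fair chance that only a limit is reported.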

Compound 4, half-maximal inhibitory concentration: > 60000 nM
Compound 4: a limit, no number; the forecaster's own chance of this, stated with the estimate: 55%; middle value at least 1.0-fold (0.03 log units) away from the limit.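

In this assay compound 4 gives > 60000 nM, which is a limit of the assay and not a number. On these data alone, the change on the saturated chain carbon bound to a sulfur now has a first readable step, an at least 1.2-fold higher number from compound 3 to compound 4 (0.11 log units; that floor lies within the scatter), so ethoxycarbonyl in place of methyl gives no sign of stronger inhibition, and the size of any loss stays unknown. For the compounds shown here, compound 3 remains the only compound here with a number, while the rest of the series sits at the limit: the limit of > 60000 nM in this assay, at which 3 of the 4 values shown sit.

As far as these compounds go, whether a carboxylic acid or a longer alkyl chain on this carbon would give a number rather than a limit stays open. From the compounds shown here alone, the effect of an amine at the same place is also open, as is any comparison among the compounds that stand only at the limit.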